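The source may hold more compounds than are shown below. What is called first, only, known or untested is meant among the compounds shown, and "the series" means these compounds.

Working notes on the series. The measured members share one core and differ in the side chain and the aryl substituent: compound 1 `NS(=O)(=O)NCCSc1nonc1/C(=N/O)Nc1ccc(F)c(Br)c1`, compound 2 `C[C@H](CSc1nonc1/C(=N/O)Nc1ccc(F)c(Br)c1)NC(=O)CS(N)(=O)=O` and compound 3 `NS(=O)(=O)CC(=O)NCCSc1nonc1/C(=N/O)Nc1ccc(F)c(C(F)F)c1`. In an assay for inhibition of Indoleamine 2,3-dioxygenase 1 (Homo sapiens), read by fluorescence, with a stated time of 1 h (on this read-out higher numbers stand for weaker inhibition and lower numbers for stronger inhibition), compound 1 gives 130 nM. In this assay compound 2 gives 110 nM, and in the same read-out compound 3 gives 73 nM. Compound 1 has the highest number of the three, but its gap to compound 2 and its gap to compound 3 both lie within the usual scatter of repeated measurements, so the three measured values do not separate from one another.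

Compound 4 `NS(=O)(=O)CC(=O)NCCSc1nonc1/C(=N/O)Nc1ccc(F)c(Br)c1` has not yet been measured. Relative to compound 1 the change is (sulfamoylmethyl)carbonyl in place of sulfamoyl on an amine nitrogen. Within the data shown here, compound 3 carries the same (sulfamoylmethyl)carbonyl on its amine nitrogen and compound 2 carries it as well; both give numbers within the scatter of compound 1, so nothing measured so far shows this change moving the read-out beyond the scatter. The step from compound 1 to compound 4 in this assay is expected to be small, a 1.5-fold lower number from compound 1 to compound 4 (0.18 log units; within the scatter), toward a lower number if anything. Compound 4 is estimated to give 85 nM in this assay, with a range from 40 nM to 180 nM.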

Compound 4, half-maximal inhibitory concentration: 71 nM
The estimate for compound 4 lay 1.2-fold (0.08 log units) above the measured number; the range from low to high includes it.
By their numbers in this assay, from the lowest: compounds 4, 3, 2 and 1 (each within the scatter of the next).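

In this assay, among these compounds, compound 1 and compound 4 form the first comparison that isolates this amine nitrogen, and (sulfamoylmethyl)carbonyl in place of sulfamoyl gives a step that stays within the scatter (a 1.8-fold lower number from compound 1 to compound 4 (0.26 log units; within the scatter)). The other single-place comparisons also stay within the scatter, both for bromo in place of difluoromethyl on an aromatic carbon (a 1.0-fold lower number from compound 3 to compound 4 (0.01 log units; within the scatter)) and for hydrogen in place of methyl on the saturated chain carbon bound to an amide-type nitrogen and a saturated chain carbon (a 1.5-fold lower number from compound 2 to compound 4 (0.19 log units; within the scatter)), so none of the three changes moves the read-out beyond the scatter among these four compounds. No separate measurement is at hand that could explain these small steps.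

The compounds shown leave open whether a carboxylic acid, a nitrile or a simple amine in place of sulfamoyl on this amine nitrogen would give a step beyond the scatter. They also leave open whether a longer chain in place of (sulfamoylmethyl)carbonyl, or chloro or trifluoromethyl in place of bromo on the aromatic carbon, would do so.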